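Swapping the halogen-bearing phenoxy group on compound 3

The source may hold more compounds than are shown below. What is called first, only, known or untested is meant among the compounds shown, and "the series" means these compounds.

Measured in an assay for inhibition of Thromboxane-A synthase (Homo sapiens), using microsomes; a lower number here means a stronger inhibitor, a higher number a weaker inhibitor:
compound 1 `O=C(O)CC/C=C\CC1COC(c2cccnc2)OC1c1cccnc1`: 220 nM
compound 2 `O=C(O)CC/C=C\CC1COC(c2cccs2)OC1c1cccnc1`: 71 nM
compound 3 `CC(C)(Oc1ccc(F)cc1)C1OCC(C/C=C\CCC(=O)O)C(c2cccnc2)O1`: 51 nM

Compound 3 gives the lowest of the three numbers. Its nearest neighbour is compound 2, and the gap between them lies within the scatter, so the two cannot be placed in order. Compound 1 lies furthest away, beyond the scatter, so compound 3 is a clearly stronger inhibitor than compound 1.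

Among the compounds with values here, the only step between two measured compounds that differ in one place is a 3.1-fold lower number from compound 1 to compound 2 (0.49 log units; beyond the scatter). It concerns the group on a saturated ring carbon of the shared core and says nothing about the side group attached through oxygen.

Compound 4 `CC(C)(Oc1ccccc1Br)C1OCC(C/C=C\CCC(=O)O)C(c2cccnc2)O1` differs from compound 3 in exactly that side group: 2-bromophenyl in place of 4-fluorophenyl on an oxygen on a saturated carbon. Within the data shown here, no measured step touches this part of the molecule, so there is nothing to point in either direction. The change keeps the size of the group and its lack of donors and acceptors, and the expectation is therefore a step from compound 3 to compound 4 of a 1.1-fold higher number from compound 3 to compound 4 (0.03 log units; within the scatter), that is, none beyond the scatter, with wide uncertainty.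

Compound 4 is estimated at 55 nM in this assay, within a range from 15 nM to 200 nM.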

Compound 4, half-maximal inhibitory concentration: 29 nM
Estimate against measurement, compound 4: 1.9-fold (0.28 log units) above, and the stated range covers the measured number.
By their numbers in this assay, from the lowest: compounds 4, 3 and 2 (each within the scatter of the next, the first and the last beyond it); then compound 1.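

Within the data shown here, this is the first measured step at the side group on the oxygen. In this assay the change from 4-fluorophenyl to 2-bromophenyl gives a 1.8-fold lower number from compound 3 to compound 4 (0.25 log units; within the scatter) and that step lies within the scatter, so compound 3 and compound 4 cannot be placed in order. The two groups match in what can be counted, including heavy atoms and hydrogen-bond donors and acceptors, but they differ in both the halogen and where it sits on the ring, and this double change shifts the number by no more than repeat measurements would. No evidence is available here on what lies behind this result.

Because the halogen and its place on the ring changed together, this single pair cannot show what either change does alone, and the two effects could be small or could offset each other. It also leaves open whether this position accepts a plain phenyl with no halogen, or a ring carrying an amine or a carboxylic acid, or whether a longer chain between the oxygen and the ring would keep the number in this range.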